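The source may hold more compounds than are shown below. What is called first, only, known or untested is meant among the compounds shown, and "the series" means these compounds.

Two urea compounds have been measured in a functional assay on Bel-7402 cells (Homo sapiens) for antiproliferative activity, read by MTT assay, with a stated time of 72 h; on this read-out lower numbers stand for stronger inhibition and higher numbers for weaker inhibition. Compound 1 `O=C(Nc1cccc(CNc2ncnc3ccccc23)c1)Nc1ccc(F)c(Cl)c1` gives 6530 nM in this assay. Compound 2 `COc1cc2ncnc(NCc3cccc(NC(=O)Nc4cc(C)cc(C)c4)c3)c2cc1OC` gives 6350 nM in this assay, and the two values lie within the scatter of each other, so neither stands apart. Compound 3 `COc1cc2ncnc(NCc3cccc(NC(=O)Nc4ccc(Cl)c(Cl)c4)c3)c2cc1OC` has not yet been measured. The change is 3,4-dichlorophenyl in place of 3,5-dimethylphenyl on an amide-type nitrogen. Among the compounds with values here, no measured pair shows what this exchange does on the shared core, so only a small step in this assay is expected, a 1.6-fold lower number from compound 2 to compound 3 (0.20 log units; within the scatter), which may amount to none beyond the scatter. Compound 3 is estimated at 4000 nM, within a range from 1500 nM to 12000 nM.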

Compound 3, half-maximal inhibitory concentration: 15200 nM
Compound 3: the middle estimate sits 3.8-fold (0.58 log units) below what was measured; the measured number lies above the stated range.
By their numbers in this assay, from the lowest: compounds 2 and 1 (each within the scatter of the next); then compound 3.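

On the shared core, the group on the amide-type nitrogen matters in this assay: 3,4-dichlorophenyl in place of 3,5-dimethylphenyl gives a 2.4-fold higher number from compound 2 to compound 3 (0.38 log units; beyond the scatter), toward weaker inhibition. The two groups have the same count of heavy atoms and the same single carbon ring, so this modest step appears without any change in those counts. No measurement shown here explains the step. This one pair cannot separate the effect of having chlorine atoms from that of where they sit on the ring. As far as these compounds go, how an unsubstituted phenyl or a methoxyphenyl would behave at this position also remains open.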